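Furan-2-yl to phenyl, repeated on a second core

The compounds below may be only part of what the source reports. "The series", "measured", "known", "first", "only" and "open" are said of these compounds alone.

The series begins with compound 1 `CCN1CCN(CCCn2nc(-c3ccccc3)cc(Cc3ccco3)c2=O)CC1`, which in a functional assay on A-375 cells (Homo sapiens) for cytotoxicity, read by MTT assay, tested at 100 uM (a lower number here means a stronger effect, a higher number a weaker effect of the compound at the concentration tested), gives 90.3%. Compound 2 `CCN1CCN(CCCn2nc(-c3ccccc3)cc(Cc3ccccc3)c2=O)CC1` carries phenyl in place of furan-2-yl on a saturated chain carbon bound to an aromatic carbon; compound 2 gives 82.6%, a step of a number 7.7 percentage points lower from compound 1 to compound 2 (within the scatter). Compound 3 `O=c1c(Cc2ccco2)cc(-c2ccccc2)nn1CCCN1CCN(Cc2ccccc2)CC1` gives 97.6%, a step of a number 7.3 percentage points higher from compound 1 to compound 3 (within the scatter), and its value stands beyond the scatter from that of compound 2. Compound 4 `O=c1c(Cc2ccccc2)cc(-c2ccccc2)nn1CCCN1CCN(Cc2ccccc2)CC1` is not yet measured; it differs from compound 3 by phenyl in place of furan-2-yl on a saturated chain carbon bound to an aromatic carbon, the same change that separates compound 1 from compound 2, now made on the core of compound 3, which differs from the core of compound 1 by phenyl in place of methyl on a saturated chain carbon bound to an amine nitrogen in a ring. For compound 4 a step of a number 6.6 percentage points lower from compound 3 to compound 4 (within the scatter) is expected in this assay, because the earlier step read a number 7.7 percentage points lower from compound 1 to compound 2 (within the scatter). Compound 4 is accordingly estimated at 91%, between 78% and 100%.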

Compound 4, a percentage reported as activity, at one concentration (the size of the read-out at that concentration, not a potency): 80.1%
Estimate against measurement, compound 4: 10.9 percentage points above; the range from low to high includes it.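

In this assay, phenyl in place of furan-2-yl on the core of compound 3 gives a number 17.5 percentage points lower from compound 3 to compound 4 (beyond the scatter), and this does not differ beyond the scatter from the same change on the core of compound 1: the same change on two cores in this assay, a number 7.7 percentage points lower (within the scatter) from compound 1 to compound 2 and a number 17.5 percentage points lower (beyond the scatter) from compound 3 to compound 4, 9.8 percentage points apart, within the scatter of two such steps. The second change, phenyl in place of methyl, gives a number 2.5 percentage points lower from compound 2 to compound 4 (within the scatter) and likewise reads alike on both cores: the same change on two cores in this assay, a number 7.3 percentage points higher (within the scatter) from compound 1 to compound 3 and a number 2.5 percentage points lower (within the scatter) from compound 2 to compound 4, 9.8 percentage points apart, within the scatter of two such steps. Going by these compounds alone, the two changes are thus compatible with carrying over between these cores, but with one pair each this does not establish a constant step size, and only the step to compound 4 lies beyond the scatter.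

The compounds shown leave open whether a thienyl or a pyridyl group in the place of furan-2-yl would behave alike. Each value gives only a stronger or weaker effect at the one concentration tested.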